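The source may report more compounds than this note shows. Statements on the series, on what has been measured and on what is new or still open speak of the compounds shown alone.

Compound 1 `O=C(N[C@H]1CN(S(=O)(=O)c2ccccc2)C[C@@H]1C(=O)N[C@H]1CCCNC1)c1cn(C2CC2)cn1` gives in an ADME assay on cells (Hepatocyte, Rattus norvegicus) for metabolic stability (a higher number here means faster removal of the compound, a lower number slower removal), a limit of < 1 uL/min, which is a limit of the assay and not a number.
Compound 2 `O=C(N[C@H]1CN(S(=O)(=O)c2ccccc2)C[C@@H]1C(=O)N[C@H]1CCCNC1)c1cc(-c2ccc(Cl)cc2)on1` gives in this assay 2.22 uL/min.
Compound 3 `O=C(N[C@H]1CN(S(=O)(=O)c2ccccc2)C[C@@H]1C(=O)N[C@H]1CCCNC1)c1cc(-c2ccccc2Cl)on1` gives in this assay 8.3 uL/min.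

Among the two real numbers, compound 3 stands highest, with a 3.7-fold higher number from compound 2 to compound 3 (0.57 log units; beyond the scatter) separating it from its nearest neighbour. Compound 1 sits at the limit (the limit of < 1 uL/min in this assay, at which 1 of the 3 values shown sits). The two steps away from compound 1 are an at least 2.2-fold higher number from compound 1 to compound 2 (0.34 log units; beyond the scatter) and an at least 8.3-fold higher number from compound 1 to compound 3 (0.91 log units; beyond the scatter), both at the group on the carbonyl carbon.

Compound 4 `CN(C(=O)[C@H]1CN(S(=O)(=O)c2ccccc2)C[C@@H]1NC(=O)c1cc(-c2ccccc2Cl)on1)[C@H]1CCCNC1` keeps everything of compound 3 and changes one place: methyl in place of hydrogen on an amide-type nitrogen. For the measured compounds named here, none of the measured steps touches this amide-type nitrogen; all of them concern the group on the carbonyl carbon at the other end of the shared core, so none of them bears directly on this change. Going by the values given here, with no step to lean on, the expectation for compound 4 is a number close to that of compound 3, with the step of a 1.1-fold higher number from compound 3 to compound 4 (0.04 log units; within the scatter) expected to stay within the scatter. Compound 4 is therefore estimated at 9 uL/min, ranging from 3 uL/min to 27 uL/min.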

Compound 4, intrinsic clearance in a liver preparation (reported as CLH), per the amount of preparation that the assay uses: 5.8 uL/min
Estimate against measurement, compound 4: 1.6-fold (0.19 log units) above; low and high end bracket the measured number.
By their numbers in this assay, from the lowest: compound 2; then compounds 4 and 3 (each within the scatter of the next). At a limit, below all of these: compound 1.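

Methyl on the amide-type nitrogen, in place of the amide hydrogen of compound 3, is the only change shown at this position, and in this assay it gives a 1.4-fold lower number from compound 3 to compound 4 (0.16 log units; within the scatter). This step therefore stays within the usual spread of repeat measurements, whereas each step shown at the group on the carbonyl carbon lies beyond it, so in this pair the change at the nitrogen makes no readable difference to the clearance number. Nothing measured here gives a reason for this result.

Going by these compounds, an ethyl group, a longer chain or a chain ending in an amine on this nitrogen remains open. So does whether methyl would behave the same way with the 1-cyclopropyl-1H-imidazol-4-yl group of compound 1 or the 5-(4-chlorophenyl)-1,2-oxazol-3-yl group of compound 2.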